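The source may report more compounds than this note shows. Statements on the series, on what has been measured and on what is new or still open speak of the compounds shown alone.

Measured in a functional assay on MOLT-4 cells (Homo sapiens) for inhibition, read by MTT assay, with a stated time of 72 h; on this read-out higher numbers stand for weaker inhibition and lower numbers for stronger inhibition:
- compound 1 `COc1cc(NC(C)CCCNC(=O)NNC(=O)Nc2ccc(Cl)cc2)c2ncccc2c1`: 186000 nM
- compound 2 `COc1cc(NC(C)CCCNC(=O)Nc2ccc(F)cc2)c2ncccc2c1`: 24000 nM
- compound 3 `COc1cc(NC(C)CCCNC(=O)Nc2cccc(O)c2)c2ncccc2c1`: 24000 nM

Compound 3 stands level with compound 2, the two together giving the lowest of the three numbers. Compound 4 `COc1cc(NC(C)CCCNC(=O)Nc2ccc(Cl)cc2)c2ncccc2c1` carries 4-chlorophenyl in place of 3-hydroxyphenyl on an amide-type nitrogen. For the measured compounds named here, the closest precedent is the exchange of 4-fluorophenyl for 3-hydroxyphenyl at that nitrogen, which gave no change at the digits printed from compound 2 to compound 3 (within the scatter). The larger steps, a 7.8-fold lower number from compound 1 to compound 2 (0.89 log units; beyond the scatter) and a 7.8-fold lower number from compound 1 to compound 3 (0.89 log units; beyond the scatter), remove the ((4-chlorophenyl)carbamoyl)amino group and bear less directly on this change. No step beyond the scatter is therefore expected in this assay, and the expected step is a 1.2-fold lower number from compound 3 to compound 4 (0.08 log units; within the scatter). Compound 4 is estimated at 20000 nM, within an expected range of 9000 nM to 45000 nM.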

Compound 4, half-maximal inhibitory concentration: 24000 nM
Beside the measured number, compound 4's estimate is 1.2-fold (0.08 log units) below it, and the stated range covers the measured number.
By their numbers in this assay, from the lowest: compounds 2, 3 and 4 (each within the scatter of the next); then compound 1.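

In this assay the amide-type nitrogen accepts 4-chlorophenyl in place of 3-hydroxyphenyl, with no change at the digits printed from compound 3 to compound 4 (within the scatter) even though the hydrogen-bond donor and acceptor counted on the leaving group are gone. Chloro in place of fluoro on an aromatic carbon gives no change at the digits printed from compound 2 to compound 4 (within the scatter) and 4-chlorophenyl in place of ((4-chlorophenyl)carbamoyl)amino gives a 7.8-fold lower number from compound 1 to compound 4 (0.89 log units; beyond the scatter) in this short series. No measurement on hand explains these results.

On these data alone, whether an amine or a carboxylic acid on the aromatic ring would shift the number stays open. So does the effect of a longer chain between the amide-type nitrogen and that ring.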